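Dropping the Chloro From Compound 1

This account rests on a few compounds, and the source may have more. Where it says the series, first, only, none or still open, it means among the compounds named here.

Compound 1, `O=C(Nc1cccc(Cl)c1)c1cccc2oc(=O)[nH]c12`, gives 68 nM.
Compound 2, `O=C(Nc1cccc(Cl)c1)c1cccc2[nH]c(=O)oc12`, gives > 10000 nM, which is a limit of the assay and not a number.

These values come from an assay on isolated protein for binding affinity to metabotropic glutamate receptor 5 (Homo sapiens); a lower number here means a stronger inhibitor, a higher number a weaker inhibitor. Compound 1 holds the only number shown. For compound 2 the result is only a limit: the limit of > 10000 nM in this assay, at which 1 of the 2 values shown sits. Compound 3, `O=C(Nc1ccccc1)c1cccc2oc(=O)[nH]c12`, is not yet measured. It differs from compound 1 by hydrogen in place of chloro on an aromatic carbon. No measured step of this kind exists among these compounds, so the size of the change is uncertain; a modest loss of affinity, somewhat beyond the scatter, seems more likely than a gain. Compound 3 is expected to give 300 nM, between 80 nM and 1500 nM. The expected step is a 4.4-fold higher number from compound 1 to compound 3 (0.64 log units; beyond the scatter).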

Compound 3, inhibition constant: 2200 nM
Compound 3: middle estimate off by 7.3-fold (0.87 log units), on the low side; the measured number lies above the stated range.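

Removing the chloro is far from a minor edit: in this assay the change is a 32-fold higher number from compound 1 to compound 3 (1.51 log units; beyond the scatter), so this one atom, on an aromatic carbon meta to a large group, accounts for much of the affinity of compound 1. Nothing shown here explains why a single chlorine matters this much.

Going by these compounds, whether chlorine itself is needed stays open, since a fluoro, bromo, methyl or methoxy group in the same place could match it or fall short. A single step at this position gives no trend across groups.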